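Methylating the phenol oxygen of compound 1

A few compounds are considered here, and "the series" means these few. Any claim that something is new, unique, unknown or untested is made for them only; others in the source may bear on it.

Series notes. Compound 1 `O=S(=O)(NCCCNc1nccc(-c2c(-c3cccc(O)c3)nc3sccn23)n1)c1cccc(F)c1` is the reference point. In an assay on isolated protein for inhibition of BDNF/NT-3 growth factors receptor (Homo sapiens), read by polymerase chain reaction, with a stated time of 1 h (on this read-out higher numbers stand for weaker inhibition and lower numbers for stronger inhibition), compound 1 gives 10300 nM, the highest of the two numbers in hand. Going by the values given here, the only other measured member, compound 2 `O=S(=O)(NCCNc1nccc(-c2c(-c3cccc(O)c3)nc3sccn23)n1)c1ccc(F)cc1`, gives 8710 nM in this assay; the step of a 1.2-fold lower number from compound 1 to compound 2 (0.07 log units; within the scatter) alters the chain and the sulfonyl aryl together and lies within the scatter.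

Compound 3 `COc1cccc(-c2nc3sccn3c2-c2ccnc(NCCCNS(=O)(=O)c3cccc(F)c3)n2)c1` is not yet measured. It differs from compound 1 by methyl in place of hydrogen on an oxygen on an aromatic ring; one bond further out this reads hydroxy to methoxy. Among the compounds with values here, no measured step touches this oxygen. Within the data shown here, the single step in hand, between compound 1 and compound 2, concerns the other end of the molecule and was itself within the scatter, so it offers no lead on direction or size for the present change. With nothing else to go on, the number for compound 3 is expected to sit near that of compound 1, with room for a modest drift toward a weaker number. The expected step for compound 3 is a 1.5-fold higher number from compound 1 to compound 3 (0.16 log units; within the scatter). Compound 3 is estimated at 15000 nM in this assay, within a range of 5000 nM to 50000 nM.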

Compound 3, half-maximal inhibitory concentration: 7580 nM
For compound 3 the middle estimate is 2.0-fold (0.30 log units) above the measured one; the measured number falls inside the stated range.
By their numbers in this assay, from the lowest: compounds 3, 2 and 1 (each within the scatter of the next).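

Going by these compounds alone, the hydroxy to methoxy change gives the first reading at this oxygen on an aromatic ring: in this assay the step is a 1.4-fold lower number from compound 1 to compound 3 (0.13 log units; within the scatter). In this one pair, methyl can therefore take the place of the hydrogen on that oxygen with no step beyond the scatter, so 3-methoxyphenyl and 3-hydroxyphenyl cannot be told apart in this assay on the chain and sulfonyl aryl of compound 1. No outside measurement bears on this result, and the pair alone gives no reason for it.

Still open, as far as these compounds go, is whether a longer group on this oxygen, such as ethoxy or benzyloxy, or an amine or a carboxylic acid in place of the hydroxy, would give a step beyond the scatter, since all steps in hand lie within it and the range this position can span is unknown. Also open, from the compounds shown here alone, is whether hydroxy to methoxy reads the same on the shorter chain and 4-fluorophenyl sulfonyl group of compound 2, as the change has been read only against compound 1.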